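Swapping the amide substituent of compound 3

The compounds below may be only part of what the source reports. "The series", "measured", "known", "first", "only" and "open" are said of these compounds alone.

Compound 3 `O=C1C(=O)N(Cc2cn(CC(=O)N3CCNCC3)nn2)c2c(Cl)ccc(Cl)c21` carries a piperazin-1-yl group on a carbonyl carbon. In a toxicity assay on GES1 cells (Homo sapiens) for inhibition, read by CCK-8 assay, with a stated time of 72 h (a lower number here means a stronger inhibitor, a higher number a weaker inhibitor), compound 3 gives "nd(insoluble)" (no result reported), so no number stands for it. Two close relatives were measured. Compound 1 `O=C1C(=O)N(Cc2cn(CC(=O)N3CCOCC3)nn2)c2c(Cl)ccc(Cl)c21` bears a morpholin-4-yl group at the same carbonyl. In this assay compound 1 gives > 128000 nM, which is a limit of the assay rather than a number. Compound 2 `O=C(Cn1cc(CN2C(=O)C(=O)c3c(Cl)ccc(Cl)c32)nn1)NC1CCCCC1` has a cyclohexylamino group in place of that morpholin-4-yl. In this assay compound 2 gives 47400 nM. Going by the values given here, the step of an at least 2.7-fold lower number from compound 1 to compound 2 (0.43 log units; beyond the scatter) is the only change measured at this carbonyl, and its full size is unknown because the limit of > 128000 nM in this assay, at which 1 of the 3 values shown sits, caps what compound 1 can show.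

Compound 4 `O=C(Cn1cc(CN2C(=O)C(=O)c3c(Cl)ccc(Cl)c32)nn1)Nc1ccccc1` differs from compound 3 by anilino in place of piperazin-1-yl on a carbonyl carbon. Like the step from compound 1 to compound 2, this trades a ring joined through its own nitrogen for a ring hung on an amide nitrogen that keeps the amide hydrogen. On that basis a number near that of compound 2 is expected for compound 4, with a real chance that only a limit is returned. Compound 4 is therefore estimated to give 45000 nM in this assay, between 15000 nM and 128000 nM.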

Compound 4, half-maximal inhibitory concentration: 24900 nM
Compound 4: the middle estimate sits 1.8-fold (0.26 log units) above what was measured, within the range that was stated.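

In this assay the change of phenyl in place of cyclohexyl on an amide-type nitrogen gives a 1.9-fold lower number from compound 2 to compound 4 (0.28 log units; within the scatter) and separates the aromatic ring from the saturated ring by no more than repeated measurements of one compound would differ. Anilino in place of morpholin-4-yl on a carbonyl carbon gives an at least 5.1-fold lower number from compound 1 to compound 4 (0.71 log units; beyond the scatter), and compound 4 now joins compound 2 as a second case, with none among the measured compounds going against it, where a ring on an amide nitrogen that keeps the amide hydrogen lies on the lower-number side of compound 1. From the compounds shown here alone, the full size of that step stays unknown, since the reading for compound 1 is a limit of the assay and not a number: the limit of > 128000 nM in this assay, at which 1 of the 4 values shown sits.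

Compound 3 still has no number, and any step to or from it cannot be read, leaving the piperazin-1-yl group without a place in this comparison. Open too, going by these compounds, is how the number would move with a shorter group on the amide nitrogen, such as methyl, or with a carboxylic acid or an amine on the phenyl ring of compound 4.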